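Amide-end variation in the aminoketone series

The compounds below may be only part of what the source reports. "The series", "measured", "known", "first", "only" and "open" are said of these compounds alone.

Measured compounds in an assay for inhibition of Nitric oxide synthase, inducible (Homo sapiens), read by scintillation counting, with a stated time of 30 min, tested at 1 mM; a lower number here means less inhibition, a higher number more inhibition at the concentration tested (going by the name of the read-out):
compound 1 `CCCC(=O)NCCC(=O)c1cc(OC)ccc1N` gives 7.35%
compound 2 `COc1ccc(N)c(C(=O)CCNC(=O)C2CC2)c1` gives 2.66%
compound 3 `COc1ccc(N)c(C(=O)CCNC(=O)C2CCCCC2)c1` gives 9.24%

All three share one core and differ only in the group on the amide carbonyl carbon. Compound 3 gives the highest of the three numbers, yet a number 1.9 percentage points higher from compound 1 to compound 3 (within the scatter) and a number 6.6 percentage points higher from compound 2 to compound 3 (within the scatter) are both within the scatter, so the three compounds are not separated in this assay; likewise a number 4.7 percentage points lower from compound 1 to compound 2 (within the scatter) lies within the scatter.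

Compound 4 `COc1ccc(N)c(C(=O)CCNC(=O)c2ccccc2)c1` is not yet measured. The change from compound 3 is phenyl in place of cyclohexyl on a carbonyl carbon. Among the measured compounds shown here, the steps that bear on it are those at the same carbonyl carbon, propyl to cyclohexyl and cyclopropyl to cyclohexyl, and both stayed within the scatter. For the measured compounds named here, no measured step replaces a non-aromatic ring by an aromatic ring, so there is no direct precedent. Given that every change so far at this position left the number within the scatter, no step beyond the scatter is expected for compound 4, a number 1.2 percentage points lower from compound 3 to compound 4 (within the scatter) being the expected step. Compound 4 is estimated at 8%, with a range from -2% to 20%.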

Compound 4, a percentage reported as inhibition, at one concentration (the size of the read-out at that concentration, not a potency): 10.9%
For compound 4 the middle estimate is 2.9 percentage points below the measured one; the measured number falls inside the stated range.
By their numbers in this assay, from the lowest: compounds 2, 1, 3 and 4 (each within the scatter of the next).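

In this assay, phenyl in place of cyclohexyl on a carbonyl carbon gives a number 1.7 percentage points higher from compound 3 to compound 4 (within the scatter), so this position now has a replacement of a non-aromatic ring by an aromatic ring, of the same heavy-atom count, with no separable effect. The other new steps, a number 8.2 percentage points higher from compound 2 to compound 4 (within the scatter) and a number 3.6 percentage points higher from compound 1 to compound 4 (within the scatter), extend the same reading to phenyl against cyclopropyl and propyl: propyl, cyclopropyl, cyclohexyl and phenyl are not separated here, and no group at this position stands apart. No evidence at hand bears on these numbers.

Open, as far as these compounds go, is whether an amine or a carboxylic acid carried on this carbonyl carbon, or a longer chain there, would give a step beyond the scatter. Also open, from the compounds shown here alone, is what a change outside the amide end would do, since the rest of the shared core stays fixed throughout these compounds.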